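The compounds below may be only part of what the source reports. "The series", "measured", "known", "first", "only" and "open" are said of these compounds alone.

In a functional assay on HT-29 cells (Homo sapiens) for antiproliferative activity, read by MTT assay, with a stated time of 72 h (a lower number here means a stronger inhibitor, a higher number a weaker inhibitor), compound 1 `C=CC(=O)N(CC(=O)OC(C)(C)C)c1nc(-c2ccccc2)cs1` gives > 30000 nM, a limit of the assay and not a number. Compound 2 `C=CC(=O)N(CC(=O)NC1CCCCC1)c1nc(-c2ccccc2)cs1` gives > 30000 nM, which is likewise a limit and not a number. Compound 2 therefore has no numerical position in the assay, and the evidence so far consists of the limit of > 30000 nM in this assay, at which 2 of the 2 values shown sit. Within the data shown here, the only measured step, a step that the two limits leave unreadable from compound 1 to compound 2, offers no size to carry forward.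

The next compound is compound 3 `C=CC(=O)N(CC(=O)NC1COC1)c1nc(-c2ccccc2)cs1`, which keeps the core of compound 2 and changes one group: oxetan-3-yl in place of cyclohexyl on an amide-type nitrogen. In words, this places oxetan-3-yl in place of cyclohexyl on an amide-type nitrogen. Among the measured compounds shown here, no measured step of readable size bears on this exchange, so the data give no direction for it. The expectation is therefore that activity in this assay will not move beyond the scatter. The estimated change is a step that the limit leaves unreadable from compound 2 to compound 3, and it should be read as an expected absence of a clear step. In this assay the expected value for compound 3 is 40000 nM, with an estimated range from 15000 nM to 100000 nM.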

Compound 3, half-maximal inhibitory concentration: > 30000 nM
Compound 3: no number, only a limit; the forecaster's own chance of this, stated with the estimate: 85%; the middle value does not contradict the limit.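

In this assay compound 3 gives > 30000 nM, a limit of the assay and not a number. Among these compounds, no step from compound 1 or compound 2 to compound 3 can therefore be read. The compounds shown leave open whether any change on the shared core gives a measurable value, as the record stands: the limit of > 30000 nM in this assay, at which 3 of the 3 values shown sit.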